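Restoring a benzyl arm: from allyl to 4-methoxybenzyl

The compounds below may be only part of what the source reports. "The series", "measured", "known", "first", "only" and "open" are said of these compounds alone.

Of the compounds shown here, three built on the same core have been measured in a functional assay on MGC-803 cells (Homo sapiens) for inhibition, read by MTT assay, with a stated time of 72 h; a higher number here means a weaker inhibitor, a lower number a stronger inhibitor. Compound 1 `Cc1cc(Nc2cc(-c3ccccc3)[nH]n2)n2nc(SCc3ccc(C(F)(F)F)cc3)nc2n1` gives 3520 nM in this assay. Compound 2 `Cc1cc(Nc2cc(-c3ccccc3)[nH]n2)n2nc(SCc3ccccc3Br)nc2n1` gives 3650 nM. Compound 3 `C=CCSc1nc2nc(C)cc(Nc3cc(-c4ccccc4)[nH]n3)n2n1` gives 17200 nM, the highest number of the three, so it is the weakest inhibitor shown. The steps between them tell a simple story: swapping one substituted phenyl for another on the saturated chain carbon bound to the sulfur gives a 1.0-fold higher number from compound 1 to compound 2 (0.02 log units; within the scatter), while replacing either phenyl with vinyl gives a 4.9-fold higher number from compound 1 to compound 3 (0.69 log units; beyond the scatter) and a 4.7-fold higher number from compound 2 to compound 3 (0.67 log units; beyond the scatter).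

Compound 4 `COc1ccc(CSc2nc3nc(C)cc(Nc4cc(-c5ccccc5)[nH]n4)n3n2)cc1` returns a ring to that position: 4-methoxyphenyl in place of vinyl on a saturated chain carbon bound to a sulfur. Both earlier steps that removed a ring there weakened inhibition, so putting a ring back is expected to reverse that, with an estimated step of a 4.8-fold lower number from compound 3 to compound 4 (0.68 log units; beyond the scatter) in this assay. For compound 4 the value expected in this assay is 3600 nM, with a likely range from 1500 nM to 9000 nM.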

Compound 4, half-maximal inhibitory concentration: 3170 nM
For compound 4 the middle estimate is 1.1-fold (0.06 log units) above the measured one, within the range that was stated.
By their numbers in this assay, from the lowest: compounds 4, 1 and 2 (each within the scatter of the next); then compound 3.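

In this assay, 4-methoxyphenyl in place of vinyl gives a 5.4-fold lower number from compound 3 to compound 4 (0.73 log units; beyond the scatter) and provides a third ring-bearing arm on the saturated chain carbon bound to a sulfur that separates clearly from the allyl compound. Compound 4 cannot be told apart from the other two ring-bearing compounds, as a 1.2-fold lower number from compound 2 to compound 4 (0.06 log units; within the scatter) and a 1.1-fold lower number from compound 1 to compound 4 (0.05 log units; within the scatter) both lie within the scatter. Across these four compounds, then, the presence of a ring tracks with the lower numbers, while 4-methoxyphenyl, 2-bromophenyl and 4-(trifluoromethyl)phenyl cannot be separated.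

Going by these compounds, it remains open whether a longer chain carrying the phenyl ring, or a phenyl ring bearing an amine or a carboxylic acid, would follow the same pattern. Nothing available here explains why a ring at this position goes with the lower numbers.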